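A few compounds are considered here, and "the series" means these few. Any claim that something is new, unique, unknown or untested is made for them only; others in the source may bear on it.

Measured compounds in a functional assay on MDA-MB-231 cells (Homo sapiens) for antiproliferative activity, read by sulforhodamine B assay, with a stated time of 48 h; on this read-out higher numbers stand for weaker inhibition and lower numbers for stronger inhibition:
compound 1 `COc1cc(OC)c2sc(-c3ccc(N/C=C\C(=O)c4cc(OC)c(OC)c(OC)c4)cc3)nc2c1` gives 15800 nM
compound 2 `COc1ccc(C(=O)/C=C\Nc2ccc(-c3nc4cc(OC)c(OC)c(OC)c4s3)cc2)cc1[N+](=O)[O-]` gives 17100 nM
compound 3 `COc1ccc2nc(-c3ccc(N/C=C\C(=O)c4ccc(OC)c(F)c4)cc3)sc2c1` gives 1100 nM

Compound 1 stands with the second highest number of the three. Its nearest neighbour is compound 2, whose number lies within the usual scatter of it, so no order between these two can be drawn. Compound 3 gives a clearly lower number than compound 1, a gap beyond the scatter, and is the only one of the three with a number of that size.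

Compound 4 `COc1cc(OC)c2sc(-c3ccc(N/C=C\C(=O)c4ccc(OC)c(O)c4)cc3)nc2c1` has not been measured. It differs from compound 1 in one place: 3-hydroxy-4-methoxyphenyl in place of 3,4,5-trimethoxyphenyl on a carbonyl carbon. Among the compounds with values here, no pair of measured compounds shows exactly this change, so the size of the step is not known. Compound 3, with its 1100 nM, shows that a different aryl group on the carbonyl carbon can go with a much lower number than compound 1 gives, although compound 3 also carries a different core. A moderate move towards a lower number is therefore expected for compound 4, with the step from compound 1 estimated as a 3.2-fold lower number from compound 1 to compound 4 (0.50 log units; beyond the scatter). The expected value for compound 4 is 5000 nM, within a range of 1500 nM to 16000 nM.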

Compound 4, half-maximal inhibitory concentration: 7610 nM
Beside the measured number, compound 4's estimate is 1.5-fold (0.18 log units) below it; the range from low to high includes it.
By their numbers in this assay, from the lowest: compound 3; then compound 4; then compounds 1 and 2 (each within the scatter of the next).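

In this assay, 3-hydroxy-4-methoxyphenyl in place of 3,4,5-trimethoxyphenyl on a carbonyl carbon gives a 2.1-fold lower number from compound 1 to compound 4 (0.32 log units; beyond the scatter), a modest step. Within the data shown here, this is the first reading of a change at this position with the core held constant, and it shows that the aryl group on the carbonyl carbon can move the number by itself, which compound 3 could not show, as it also carries a different core. Nothing given here says why the number moves.

Among these compounds, the single step changes two things at once, so it leaves open how much of it belongs to the hydroxy group that enters and how much to the methoxy groups that leave. As far as these compounds go, whether an amine or a carboxylic acid in place of that hydroxy group would go with a lower or a higher number also remains open.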